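Replacing quinolin-8-yl by cyclohexyl on the sulfone

The source may hold more compounds than are shown below. What is called first, only, known or untested is meant among the compounds shown, and "the series" means these compounds.

Of the compounds shown here, three sharing one core have been tested in an ADME assay (liver) for metabolic stability, with Liver microsome (Homo sapiens) as the target, using microsomes, with a stated time of 30 min, tested at 1 uM; on this read-out higher numbers stand for a more stable compound and lower numbers for a less stable compound. Compound 1 `N#C/N=C(\NCc1ccc(S(=O)(=O)c2cccc(C(F)(F)F)c2)cc1)Nc1ccncc1` gives 62%. Compound 2 `N#C/N=C(\NCc1ccc(S(=O)(=O)c2ccccc2)cc1)Nc1ccncc1` gives 96%. Compound 3 `N#C/N=C(\NCc1ccc(S(=O)(=O)c2cccc3cccnc23)cc1)Nc1ccncc1` gives 10%, which is the lowest of the three numbers: the step of a number 52 percentage points lower from compound 1 to compound 3 (beyond the scatter) and the step of a number 86 percentage points lower from compound 2 to compound 3 (beyond the scatter) both place compound 3 well beyond the scatter below the other two, so among the measured compounds it is the least stable in this assay.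

The next compound keeps everything except the group on the sulfonyl sulfur. Compound 4 `N#C/N=C(\NCc1ccc(S(=O)(=O)C2CCCCC2)cc1)Nc1ccncc1` differs from compound 3 in one place: cyclohexyl in place of quinolin-8-yl on a sulfonyl sulfur.

For the measured compounds named here, no measured step involves a cyclohexyl group, so the only guide is what happened when quinolin-8-yl came in. Both steps that introduced it, a number 52 percentage points lower from compound 1 to compound 3 (beyond the scatter) and a number 86 percentage points lower from compound 2 to compound 3 (beyond the scatter), were large falls. Taking quinolin-8-yl away again is therefore expected to reverse most of that fall, and a large rise is estimated, as expressed by a number 50 percentage points higher from compound 3 to compound 4 (beyond the scatter). Without any comparison for cyclohexyl itself the estimate is broad: compound 4 is expected to give about 60% in this assay, with a likely range from 25% to 92%.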

Compound 4, percent of the compound remaining in the Liver microsome assay: 56%
Beside the measured number, compound 4's estimate is 4 percentage points above it, and the stated range covers the measured number.
By their numbers in the Liver microsome assay, from the lowest: compound 3; then compounds 4 and 1 (each within the scatter of the next); then compound 2.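

In the Liver microsome assay, a non-aromatic ring on the sulfonyl sulfur gives a middle position rather than an extreme: a number 46 percentage points higher from compound 3 to compound 4 (beyond the scatter), yet a number 40 percentage points lower from compound 2 to compound 4 (beyond the scatter). The aromatic groups therefore fall on both sides of cyclohexyl, so aromatic versus non-aromatic does not sort these four compounds, with quinolin-8-yl and phenyl going opposite ways, while a number 6 percentage points lower from compound 1 to compound 4 (within the scatter), leaving cyclohexyl and 3-(trifluoromethyl)phenyl indistinguishable on this read-out. This change is also separated in a physicochemical assay for solubility, with a stated time of 24 h (on this read-out higher numbers stand for higher solubility and lower numbers for lower solubility), where compound 3 gives 18000 nM. In the physicochemical assay compound 4 gives > 100000 nM, which is a limit of the assay and not a number. In the physicochemical assay the step reads as an at least 5.5-fold higher number from compound 3 to compound 4 (0.74 log units; beyond the scatter) and its full size stays unknown: the limit of > 100000 nM in the physicochemical assay, at which 1 of the 2 values shown sits.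

Still open, as far as these compounds go, is how an oxygen- or nitrogen-containing saturated ring, such as morpholine or piperidine, or an open chain such as ethyl, would behave on the sulfonyl sulfur in the Liver microsome assay. The compounds shown also cannot separate the part played by cyclohexyl entering from that of quinolin-8-yl leaving in the physicochemical assay.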